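The source may hold more compounds than are shown below. What is called first, only, known or untested is meant among the compounds shown, and "the series" means these compounds.

Compound 1 `CC(C)[C@@H](CC(=O)O)NC(=O)[C@@H]1CCCN1S(=O)(=O)c1cc(Cl)cc(Cl)c1`: 8.9 nM
Compound 2 `O=C(O)CCNC(=O)[C@@H]1CCCN1S(=O)(=O)c1cc(Cl)cc(Cl)c1`: 1510 nM

In an assay on RPMI-8866 cells for inhibition of integrin alpha-4/beta-1 (Homo sapiens) (on this read-out higher numbers stand for weaker inhibition and lower numbers for stronger inhibition), compound 2 stands highest of the two numbers. The only step shown, a 170-fold higher number from compound 1 to compound 2 (2.23 log units; beyond the scatter), is large and concerns the very place that now changes again. Compound 3 `O=C(O)C[C@@H](NC(=O)[C@@H]1CCCN1S(=O)(=O)c1cc(Cl)cc(Cl)c1)c1ccc(O)cc1` differs from compound 2 by 4-hydroxyphenyl in place of hydrogen on a saturated chain carbon bound to an amide-type nitrogen and a saturated chain carbon. Given the step of a 170-fold higher number from compound 1 to compound 2 (2.23 log units; beyond the scatter), restoring a substituent at this position is expected to move the number strongly in the opposite direction, so for compound 3 a large step downward is expected: a 76-fold lower number from compound 2 to compound 3 (1.88 log units; beyond the scatter). Compound 3 is therefore estimated at 20 nM, within a range from 3 nM to 150 nM.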

Compound 3, half-maximal inhibitory concentration: 0.74 nM
Estimate against measurement, compound 3: 27-fold (1.43 log units) above, and the stated range ends above it.
By their numbers in this assay, from the lowest: compound 3; then compound 1; then compound 2.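

Putting 4-hydroxyphenyl on this saturated chain carbon gives a 2000-fold lower number from compound 2 to compound 3 (3.31 log units; beyond the scatter) and so takes the number well past where isopropyl had brought it. The kind of substituent therefore counts, not only its presence: 4-hydroxyphenyl in place of isopropyl gives a 12-fold lower number from compound 1 to compound 3 (1.08 log units; beyond the scatter) at the same carbon. No measured evidence here explains this difference.

The compounds shown leave open whether the ring itself or its hydroxyl accounts for the stronger inhibition. A plain phenyl group, or a phenyl ring carrying an amine instead, would help separate the two.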